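Removing an aziridine from a tris-aziridinyl quinone

A few compounds are considered here, and "the series" means these few. Any claim that something is new, unique, unknown or untested is made for them only; others in the source may bear on it.

Two compounds with a shared quinone core carrying aziridin-1-yl groups have been measured in a functional assay on L1210 cells (Mus musculus), with a stated time of 12 days; on this read-out lower numbers stand for lower potency and higher numbers for higher potency (the scale is a negative logarithm). Compound 1 `CC1=C(N2CC2)C(=O)C(CC(C)OC(N)=O)=C(N2CC2)C1=O` gives 6.14 in this assay, and compound 2 `CC1=C(N2CC2)C(=O)C(N2CC2)=C(N2CC2)C1=O` gives 6.77. For the measured compounds named here, compound 2 stands highest of the two, and the only measured step, a number 0.63 log units higher from compound 1 to compound 2 (beyond the scatter), shows that exchanging a non-ring chain for an aziridin-1-yl group raised the read-out beyond the scatter.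

Compound 3 `CCC(OC)C1=C(N2CC2)C(=O)C(C)=C(N2CC2)C1=O` has not yet been measured in this assay. It differs from compound 2 by 1-methoxypropyl in place of aziridin-1-yl on a double-bonded ring carbon. Going by the values given here, this change runs in the opposite sense to the one measured step, in which a non-ring group was replaced by an aziridin-1-yl group. A drop beyond the scatter is therefore expected, and the step from compound 2 is estimated as a number 0.67 log units lower from compound 2 to compound 3 (beyond the scatter). For compound 3 in this assay the value is expected to be 6.1, within a range from 5.5 to 6.7.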

Compound 3, logarithm of the reciprocal of the active concentration, log(1/C): 5.68
Beside the measured number, compound 3's estimate is 0.42 log units above it; the range from low to high includes it.
By their numbers in this assay, from the lowest: compound 3; then compound 1; then compound 2.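

Replacing aziridin-1-yl with 1-methoxypropyl on this double-bonded ring carbon gave, in this assay, a number 1.09 log units lower from compound 2 to compound 3 (beyond the scatter), so a second group with no ring, and not only the chain of compound 1, falls short of aziridin-1-yl here. The two groups without a ring are not equivalent either: the further change gave a number 0.46 log units lower from compound 1 to compound 3 (beyond the scatter), so the read-out at this place depends on which chain is present and not only on the loss of aziridin-1-yl. Nothing available explains this order among the three groups.

From the compounds shown here alone, it remains open whether a simple amine such as dimethylamino, or a plain ethyl chain with no oxygen, would stand nearer compound 2 or compound 3. Going by these compounds, it is also open whether a larger nitrogen ring such as azetidin-1-yl would keep the higher read-out of compound 2.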